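The compounds below may be only part of what the source reports. "The series", "measured", "known", "first", "only" and "open" are said of these compounds alone.

Compound 1 `COc1ccc(/C=C/C(=O)c2ccc(OC)c3c2OC(C)(C)C=C3)cc1O`: > 10000 nM
Compound 2 `C=CC(=O)Oc1cc(/C=C/C(=O)c2ccc(OC)c3c2OC(C)(C)C=C3)ccc1OC`: > 10000 nM

Both entries come from an ADME assay on L02 cells (Homo sapiens) for cytotoxicity, read by MTT assay; on this read-out lower numbers stand for stronger inhibition and higher numbers for weaker inhibition. Compound 1 gives > 10000 nM, which is a limit of the assay and not a number. Compound 2 gives > 10000 nM, which is also a limit. The measured compounds therefore stand together at the limit of > 10000 nM in this assay, at which 2 of the 2 values shown sit, so compound 2 has no exact place on the scale.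

Compound 3 `COc1ccc(/C=C/C(=O)c2ccc(OC)c3c2OC(C)(C)C=C3)cc1OS(=O)(=O)Cc1ccccc1` keeps the shared core and puts benzylsulfonyl in place of vinylcarbonyl on an oxygen on an aromatic ring. For the measured compounds named here, the one measured step that changes a group on this oxygen is a step that the two limits leave unreadable from compound 1 to compound 2. It shows that swapping hydrogen for vinylcarbonyl left the compound at the limit, but it offers no size to carry over to the new group. No shift in either direction can be argued from it, so compound 3 is expected to remain in the same region of this assay, quite possibly at the limit again. The estimated change is a step that the limit leaves unreadable from compound 2 to compound 3. For compound 3 the expected value is 15000 nM, with an estimated range from 6000 nM to 40000 nM.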

Compound 3, half-maximal inhibitory concentration: > 10000 nM
Compound 3 ended at the assay's limit; the forecaster's own chance of this, stated with the estimate: 80%; the middle value lies beyond the limit too.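

For the compounds shown here, compound 1, compound 2 and compound 3 all stop at one limit, so no step among them can be read, in size or in direction: the limit of > 10000 nM in this assay, at which 3 of the 3 values shown sit.
What the compounds shown leave open is how far past that limit each one lies in this assay and whether the group on this oxygen changes the value at all.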